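This account rests on a few compounds, and the source may have more. Where it says the series, first, only, none or still open, it means among the compounds named here.

Measured so far in a functional assay on A549 cells (Homo sapiens) for cytotoxicity, read by MTT assay, with a stated time of 72 h; a higher number here means a weaker inhibitor, a lower number a stronger inhibitor:
Compound 1 `O=S(=O)(c1ccccc1)c1nc2ccccc2nc1Nc1ccc(F)cc1` gives > 50000 nM, which is a limit of the assay rather than a number (the limit of > 50000 nM in this assay, at which 1 of the 3 values shown sits).
Compound 2 `O=S(=O)(c1ccccc1)c1nc2ccccc2nc1Nc1ccc(Cl)cc1` gives 30700 nM.
Compound 3 `COc1ccc(S(=O)(=O)c2nc3ccccc3nc2Nc2ccc(F)cc2)cc1` gives 1240 nM.

Compound 4 `COc1ccc(S(=O)(=O)c2nc3ccccc3nc2Nc2ccc(Cl)cc2)cc1` has not yet been measured. It differs from compound 3 by chloro in place of fluoro on an aromatic carbon. The same change, (chloro in place of fluoro on an aromatic carbon), was made once before, from compound 1 to compound 2, where it gave an at least 1.6-fold lower number from compound 1 to compound 2 (0.21 log units; that floor lies within the scatter). The two cores on which this change is made differ by methoxy in place of hydrogen on an aromatic carbon, and that change gave an at least 40-fold lower number from compound 1 to compound 3 (1.60 log units; beyond the scatter). Because the same change gave an at least 1.6-fold lower number from compound 1 to compound 2 (0.21 log units; that floor lies within the scatter), a floor that lies within the scatter, a similarly small step is expected this time too, a 1.4-fold lower number from compound 3 to compound 4 (0.14 log units; within the scatter). Compound 4 is therefore estimated at 900 nM, with four in five repeats expected between 350 nM and 3000 nM.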

Compound 4, half-maximal inhibitory concentration: 87300 nM
For compound 4 the middle estimate is 97-fold (1.99 log units) below the measured one; the measured number lies above the stated range.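

In this assay, chloro in place of fluoro does not carry from one core to the other, giving a 70-fold higher number from compound 3 to compound 4 (1.85 log units; beyond the scatter), and the two steps disagree: the same change on two cores in this assay, an at least 1.6-fold lower number (0.21 log units; that floor lies within the scatter) from compound 1 to compound 2 and a 70-fold higher number (1.85 log units; beyond the scatter) from compound 3 to compound 4, at least 110-fold (2.05 log units) apart, beyond the scatter of two such steps. Methoxy in place of hydrogen also depends on its partner group, giving a 2.8-fold higher number from compound 2 to compound 4 (0.45 log units; beyond the scatter), and these two steps disagree as well: the same change on two cores in this assay, an at least 40-fold lower number (1.60 log units; beyond the scatter) from compound 1 to compound 3 and a 2.8-fold higher number (0.45 log units; beyond the scatter) from compound 2 to compound 4, at least 110-fold (2.05 log units) apart, beyond the scatter of two such steps. This shows that the two changes do not simply add up in these compounds, but not why, and the earlier steps start from compound 1, whose value is a limit: the limit of > 50000 nM in this assay, at which 1 of the 4 values shown sits.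

The compounds shown leave open whether the mismatch is special to chloro with methoxy. A bromo in place of the chloro, or an ethoxy or an amine in place of the methoxy, could test this.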